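The source may report more compounds than this note shows. Statements on the series, on what has been measured and on what is new or still open speak of the compounds shown alone.

For the measured compounds named here, compound 2 `COc1cccc(Cn2cnc3sc(-c4ccncc4)cc3c2=O)c1` shows the higher of the two numbers measured so far in an assay on isolated protein for inhibition of Rho-associated protein kinase 1 (Homo sapiens), read by radiometric assay and 33P incorporation, with a stated time of 40 min, in the presence of a further agent that is not named here (a higher number here means a weaker inhibitor, a lower number a stronger inhibitor), giving 45 nM; compound 1 `COc1cccc(Cn2cnc3sc(-c4ccc5[nH]ncc5c4)cc3c2=O)c1` gives 20 nM. Going by the values given here, the only measured step, a 2.3-fold higher number from compound 1 to compound 2 (0.35 log units; beyond the scatter), went from a group counted with one hydrogen-bond donor to one with none. Compound 3 `COc1cccc(Cn2cnc3sc(-c4ccc(N)nc4)cc3c2=O)c1` carries the change (6-aminopyridin-3-yl in place of pyridin-4-yl on an aromatic carbon), which brings a hydrogen-bond donor back into the counted atoms. Among the compounds with values here, a modest step toward a lower number is therefore expected, a 1.8-fold lower number from compound 2 to compound 3 (0.26 log units; within the scatter), although only one earlier step supports this. Compound 3 is estimated at 25 nM, within a range from 8 nM to 80 nM.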

Compound 3, half-maximal inhibitory concentration: > 10000 nM
Compound 3: a limit, no number; the forecaster's own chance of this, stated with the estimate: 2%; middle value at least 400-fold (2.60 log units) away from the limit.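

Replacing pyridin-4-yl with 6-aminopyridin-3-yl gives an at least 220-fold higher number from compound 2 to compound 3 (2.34 log units; beyond the scatter) and replacing 1H-indazol-5-yl with it gives an at least 500-fold higher number from compound 1 to compound 3 (2.69 log units; beyond the scatter) so at this position next to the ring sulfur, a group counted with a hydrogen-bond donor does not by itself bring a lower number. For compound 3, this assay yields a limit and not a number: the limit of > 10000 nM in this assay, at which 1 of the 3 values shown sits.

The change adds an amine and also moves the ring nitrogen, and the compounds shown cannot tell these two apart. A plain pyridin-3-yl group or a 2-aminopyridin-4-yl group would separate them.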